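Three Aryl Groups, No Inhibition: Estimating a Fourth

The compounds below may be only part of what the source reports. "The series", "measured", "known", "first", "only" and "open" are said of these compounds alone.

Measured compounds:
compound 1, `Nc1scc(CN2CCN(c3ccc(Cl)c(C(F)(F)F)c3)CC2)c1C(=O)c1ccc(Cl)cc1`: 0%
compound 2, `Nc1scc(CN2CCN(c3ccncc3)CC2)c1C(=O)c1ccc(Cl)cc1`: 1%
compound 3, `Nc1scc(CN2CCN(c3cccc(F)c3F)CC2)c1C(=O)c1ccc(Cl)cc1`: 0%

All three compounds share the same core and differ only in the aryl group carried on an amine nitrogen in a ring. In an assay on CHO cells for displacement of a labelled ligand from adenosine receptor A1 (Homo sapiens), read by scintillation counting, with a stated time of 120 min, tested at 10 uM (on this read-out lower numbers stand for less inhibition and higher numbers for more inhibition at the one concentration tested (going by the name of the read-out)), compound 1 gives 0%, which is level with compound 3 and, together with it, the lowest of the three numbers; the nearest neighbour is compound 3, with no change at the digits printed from compound 1 to compound 3 (within the scatter), and the furthest is compound 2, with a number 1 percentage points higher from compound 1 to compound 2 (within the scatter). Both steps lie within the scatter, so the three aryl groups tried so far are indistinguishable on this read-out.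

Compound 4, `Nc1scc(CN2CCN(c3cc(Cl)ccc3Cl)CC2)c1C(=O)c1ccc(Cl)cc1`, is reached from compound 1 by the change (2,5-dichlorophenyl in place of 4-chloro-3-(trifluoromethyl)phenyl on an amine nitrogen in a ring). For the measured compounds named here, the steps that bear on it are the two aryl swaps from compound 1 already described, and neither moved the number beyond the scatter. The same is therefore expected here: no step beyond the scatter in this assay. For compound 4 the expected value is 0%, with a range from -5% to 8%. This estimate amounts to an expected step of no change at the digits printed from compound 1 to compound 4 (within the scatter).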

Compound 4, a percentage reported as inhibition, at one concentration (the size of the read-out at that concentration, not a potency): 0%
Estimate against measurement, compound 4: no gap at the digits printed; low and high end bracket the measured number.
By their numbers in this assay, from the lowest: compounds 1, 3, 4 and 2 (each within the scatter of the next).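

The 2,5-dichlorophenyl group behaves like the three aryl groups before it in this assay, with no change at the digits printed from compound 1 to compound 4 (within the scatter), no change at the digits printed from compound 3 to compound 4 (within the scatter) and a number 1 percentage points lower from compound 2 to compound 4 (within the scatter). The flat picture at this amine nitrogen now extends to an aryl group carrying only chlorine, and it holds when 11 heavy atoms in the leaving group give way to 8 in the entering one. No supporting measurement is available to explain why the number stays put across these compounds.

On these data alone, whether any group on this nitrogen can lift the number beyond the scatter remains open, for instance a benzyl group or a phenyl ring bearing a carboxylic acid or an amine. As far as these compounds go, all four compounds also share the rest of the structure, so it remains open whether these results would hold on a different core.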